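The source may hold more compounds than are shown below. What is called first, only, known or untested is meant among the compounds shown, and "the series" means these compounds.

a functional assay on CNE-2 cells (Homo sapiens) for antiproliferative activity, read by sulforhodamine B assay, with a stated time of 48 h (on this read-out lower numbers stand for stronger inhibition and higher numbers for weaker inhibition), values so far:
- compound 1 `COc1cccc(/C=C/C(=O)C(=Cc2ccc(O)c(F)c2)C(=O)/C=C/c2cccc(OC)c2OC)c1OC` gives 260 nM
- compound 2 `COc1cc(C=C(C(=O)/C=C/c2cccc(OC)c2OC)C(=O)/C=C/c2cccc(OC)c2OC)cc(Br)c1O` gives 220 nM
- compound 3 `COc1ccc(/C=C/C(=O)C(=Cc2ccc(O)c(OC)c2)C(=O)/C=C/c2ccc(OC)cc2OC)c(OC)c1` gives 970 nM

Compound 3 has the highest number of the three. Compound 4 `COc1ccc(/C=C/C(=O)C(=Cc2cc(OC)c(O)c(OC)c2)C(=O)/C=C/c2ccc(OC)cc2OC)c(OC)c1` differs from it by methoxy in place of hydrogen on an aromatic carbon as methoxy in place of hydrogen on an aromatic carbon, taking 4-hydroxy-3-methoxyphenyl to 4-hydroxy-3,5-dimethoxyphenyl. Going by the values given here, only one measured step bears on this, and loosely: a 1.2-fold lower number from compound 1 to compound 2 (0.07 log units; within the scatter) also ends in a 5-methoxy-bearing group and lies within the scatter. No pure methoxy addition has been measured. No step beyond the scatter is therefore expected in this assay for this change. The estimated change is a 1.4-fold lower number from compound 3 to compound 4 (0.14 log units; within the scatter) in size. Compound 4 is estimated at 700 nM with an expected range of 280 nM to 1800 nM overall.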

Compound 4, half-maximal inhibitory concentration: 850 nM
Estimate against measurement, compound 4: 1.2-fold (0.08 log units) below; measured number inside the range.
By their numbers in this assay, from the lowest: compounds 2 and 1 (each within the scatter of the next); then compounds 4 and 3 (each within the scatter of the next).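

In this assay, adding methoxy in place of hydrogen on the aromatic carbon ortho to the hydroxy group gives a 1.1-fold lower number from compound 3 to compound 4 (0.06 log units; within the scatter). Going by these compounds alone, this is the first pure methoxy addition read, and it shows that this position accepts the group without a step beyond the scatter, in this one pair only.

Going by these compounds, whether an ethoxy group, an amine or a carboxylic acid at this position would also leave the number within the scatter stays open, as does whether methoxy behaves alike on the core of compound 1. No measured property bears on this result.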